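Removing the chloro from a glycine transporter inhibitor

The source may hold more compounds than are shown below. What is called first, only, known or untested is meant among the compounds shown, and "the series" means these compounds.

Compound 1, `Cn1cnc(S(=O)(=O)NCc2ccc3c(c2)[C@@H](Cc2ccccc2)[C@@H](N2CCC2)CC3)c1`: in an assay on cells for displacement of a labelled ligand from sodium- and chloride-dependent glycine transporter 1 (Homo sapiens), read by scintillation counting, with a stated time of 1 h (a lower number here means a stronger inhibitor, a higher number a weaker inhibitor), compound 1 gives 3 nM.
Compound 2, `Cn1cnc(S(=O)(=O)NCCOc2ccc3c(c2)[C@@H](Cc2cccc(Cl)c2)[C@@H](N)CC3)c1`: in this assay compound 2 gives 1.5 nM.

For the measured compounds named here, of these two numbers, the one for compound 2 is the lower, but its gap to compound 1 lies within the usual scatter of the measurement, so the two compounds cannot be told apart on this evidence. Compounds 1 and 2 also differ from each other in several places at once, so no single change can be read out of their pair.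

Compound 3, `Cn1cnc(S(=O)(=O)NCCOc2ccc3c(c2)[C@@H](Cc2ccccc2)[C@@H](N)CC3)c1`, has not yet been measured. It differs from compound 2 in one place only: hydrogen in place of chloro on an aromatic carbon. Nothing in the measured pair speaks directly to this change, since both measured compounds carry different linkers and amines as well. In the absence of a directly comparable pair, a small loss is the expectation: the estimated step from compound 2 to compound 3 in this assay is a 2.7-fold higher number from compound 2 to compound 3 (0.43 log units; beyond the scatter), close to the edge of the scatter. Compound 3 is therefore expected to give about 4 nM, with a likely range from 1.5 nM to 12 nM.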

Compound 3, inhibition constant: 3.6 nM
Compound 3: middle estimate off by 1.1-fold (0.05 log units), on the high side; the range from low to high includes it.
By their numbers in this assay, from the lowest: compounds 2, 1 and 3 (each within the scatter of the next, the first and the last beyond it).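

For the compounds shown here, for the first time a single change can be read on its own: on going from 3-chlorophenyl to phenyl, this assay shows a 2.4-fold higher number from compound 2 to compound 3 (0.38 log units; beyond the scatter). The chloro on this aromatic carbon therefore has a measurable but modest link to the number, and it is not essential for strong inhibition, since compound 3 still gives 3.6 nM without it. No measurement at hand explains why the step has this size.

Compound 1 also carries an unsubstituted benzyl group, but its linker and amine differ from those of compound 3, so it cannot show whether the same step would hold with that linker and amine. Going by these compounds alone, the single pair also leaves open how other groups on this aromatic carbon, such as fluoro, methyl, methoxy or trifluoromethyl, would compare with chloro and hydrogen, so one step gives a first reading of this position and no general trend.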